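The source may report more compounds than this note shows. Statements on the series, on what has been measured and on what is new or still open speak of the compounds shown alone.

Measured so far:
compound 1, `CN1CCC(NC(=O)Nc2cccc3[nH]ncc23)c2cc(C(C)(C)C)ccc21` — 853 nM
compound 2, `COc1ccc2c(c1)C(NC(=O)Nc1cccc3[nH]ncc13)CCN2C` — 1380 nM

In a functional assay for antagonist activity at transient receptor potential cation channel subfamily V member 1 (Homo sapiens), read by calcium flux (a higher number here means a weaker inhibitor, a lower number a stronger inhibitor), compound 1 gives 853 nM, and compound 2 gives 1380 nM. Compound 2 thus holds the higher of the two numbers, but the step of a 1.6-fold higher number from compound 1 to compound 2 (0.21 log units; within the scatter) is within the scatter, so the two compounds cannot be ordered in this assay.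

Compound 3, `COc1ccc2c(c1)C(NC(=O)Nc1cccc3[nH]ncc13)CCN2Cc1ccccc1`, has not yet been measured. It differs from compound 2 in one place: phenyl in place of hydrogen on a saturated chain carbon bound to a nitrogen on an aromatic ring in a ring, which, cut one bond further out, reads methyl to benzyl. Going by the values given here, the only measured step, from compound 1 to compound 2, concerns a change on an aromatic carbon, not on the saturated chain carbon bound to the ring nitrogen, so nothing measured here bears directly on the change to compound 3. Among the compounds with values here, with no step at this place to draw on, the estimate for compound 3 is anchored on compound 2, and the expected step of a 1.0-fold higher number from compound 2 to compound 3 (0.01 log units; within the scatter) is set at none beyond the scatter, with a widened range. Compound 3 is therefore expected to give 1400 nM, between 400 nM and 5000 nM.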

Compound 3, half-maximal inhibitory concentration: 160 nM
Compound 3: the middle estimate sits 8.8-fold (0.94 log units) above what was measured; measured number outside the range, below it.
By their numbers in this assay, from the lowest: compound 3; then compounds 1 and 2 (each within the scatter of the next).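

In this assay, the change from methyl to benzyl gives an 8.6-fold lower number from compound 2 to compound 3 (0.94 log units; beyond the scatter), the only step among these compounds that lies beyond the scatter. This shows that the saturated chain carbon bound to a nitrogen on an aromatic ring in a ring is a place where the number responds, and that a phenyl there goes with a stronger inhibitor, whereas the earlier change on an aromatic carbon, a 1.6-fold higher number from compound 1 to compound 2 (0.21 log units; within the scatter), could not separate its two compounds. No measurement shown here explains this step.

Going by these compounds, what remains open is whether the phenyl itself matters or whether other groups at this place would serve as well, such as a cyclohexyl, a pyridine ring, a longer chain ending in phenyl, or a phenyl carrying a carboxylic acid or an amine. On these data alone, it is also open whether the same step would appear with tert-butyl in place of methoxy on the aromatic carbon, since this single pair holds the methoxy fixed.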